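From 4-cyanophenyl to 2,3-dichlorophenyl: notes on compound 4

The compounds below may be only part of what the source reports. "The series", "measured", "known", "first", "only" and "open" are said of these compounds alone.

Measured in a functional assay on HepG2 cells (Homo sapiens) for cytotoxicity, read by MTT assay, with a stated time of 72 h; a lower number here means a stronger inhibitor, a higher number a weaker inhibitor:
compound 1 `N#Cc1ccc(/C=N/NC(=O)Nc2cc3c(Nc4ccc(F)c(Cl)c4)ncnc3cc2O[C@H]2CCOC2)cc1` (26400 nM)
compound 2 `COc1cc2ncnc(Nc3ccc(F)c(Cl)c3)c2cc1NC(=O)N/N=C/c1cccc(Br)c1` ("not active" (no number reported))
compound 3 `COc1cc2ncnc(Nc3ccc(F)c(Cl)c3)c2cc1NC(=O)N/N=C/c1ccc(C#N)cc1` (34100 nM)

Compound 3 stands level with compound 1 within the scatter, and compound 2 gave no number. Compound 4 `COc1cc2ncnc(Nc3ccc(F)c(Cl)c3)c2cc1NC(=O)N/N=C/c1cccc(Cl)c1Cl` differs from compound 3 at one place (2,3-dichlorophenyl in place of 4-cyanophenyl on a carbon with a double bond to nitrogen), the carbon with a double bond to nitrogen. Among the measured compounds shown here, the one measured step (a 1.3-fold higher number from compound 1 to compound 3 (0.11 log units; within the scatter)) concerns methyl in place of oxolan-3-yl, so it gives no size for this change. Compound 2, without the nitrile, reads "not active" (no number reported) and offers only a weak hint of a higher number. The estimated step is modest and upward (a 1.3-fold higher number from compound 3 to compound 4 (0.12 log units; within the scatter)) and remains uncertain. For compound 4 the estimated value is 45000 nM with an expected range of 15000 nM to 100000 nM in this assay and a real chance of no number.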

Compound 4, half-maximal inhibitory concentration: 26100 nM
Estimate against measurement, compound 4: 1.7-fold (0.24 log units) above; measured number inside the range.
By their numbers in this assay, from the lowest: compounds 4, 1 and 3 (each within the scatter of the next).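

In this assay, replacing 4-cyanophenyl with 2,3-dichlorophenyl on the carbon with a double bond to nitrogen gives a 1.3-fold lower number from compound 3 to compound 4 (0.12 log units; within the scatter), so the two groups read alike at this position. The nitrile is therefore not needed for a numerical reading, as compound 4 has none, whereas compound 2 reads "not active". No measurement available here accounts for this result. Still open, from the compounds shown here alone, is how an amine or a carboxylic acid on this phenyl ring would read. Also open, going by these compounds, is whether 2,3-dichlorophenyl holds its reading with oxolan-3-yl in place of methyl on the oxygen.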